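Amine in place of ester on a coumarin-type migration series

This account rests on a few compounds, and the source may have more. Where it says the series, first, only, none or still open, it means among the compounds named here.

Measured so far:
compound 1, `CC(=O)OCc1ccc2oc(=O)c(C(=O)Sc3ccccc3)cc2c1`, 89.5%
compound 2, `CCCCC(=O)OCc1ccc2oc(=O)c(C(=O)Oc3cccc(Br)c3)cc2c1`, 92.4%

Both compounds were tested in a functional assay on HT-1080 cells (Homo sapiens), read by transwell migration, with a stated time of 24 h, tested at 0.1 uM; on this read-out lower numbers stand for a stronger effect and higher numbers for a weaker effect at the one concentration tested. Compound 1 gives 89.5% and compound 2 gives 92.4%; these two numbers sit within the usual scatter of each other, so nothing separates them, and both show only a weak effect on cell migration at the concentration used. Compound 2 is the reference point here, and its value leaves little room for any compound to appear weaker than it.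

Compound 3, `NCc1ccc2oc(=O)c(C(=O)Oc3cccc(Br)c3)cc2c1`, has not yet been measured. It differs from compound 2 in one place: amino in place of (butylcarbonyl)oxy on a saturated chain carbon bound to an aromatic carbon. The (butylcarbonyl)oxy group leaves and an amino group enters, on a saturated chain carbon bound to an aromatic carbon.

Among the compounds with values here, no pair of measured compounds shows what such a change does here, so the expectation rests on the two known values alone. In this assay compound 3 is expected to give 88%, in a range from 70% to 104%. The expected step of a number 4.4 percentage points lower from compound 2 to compound 3 (within the scatter) is estimated to stay within the scatter.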

Compound 3, a percentage reported as activity, at one concentration (the size of the read-out at that concentration, not a potency): 88.3%
Beside the measured number, compound 3's estimate is 0.3 percentage points below it; the range from low to high includes it.
By their numbers in this assay, from the lowest: compounds 3, 1 and 2 (each within the scatter of the next).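

Within the data shown here, replacing the (butylcarbonyl)oxy group with amino on a saturated chain carbon bound to an aromatic carbon gives a number 4.1 percentage points lower from compound 2 to compound 3 (within the scatter) in this assay and is the first one-place comparison available. It shows that a group of 7 heavy atoms with no hydrogen-bond donor can give way to a single nitrogen with a hydrogen-bond donor without the read-out moving beyond the usual scatter, so this large change in the group's size leaves no visible mark at this position under these conditions. No supporting measurement is available to explain this result.

As far as these compounds go, it remains open whether another group at this place, such as a hydroxyl, a carboxylic acid or a longer amine chain, would shift the migration read-out beyond the scatter. From the compounds shown here alone, a reading at one concentration also cannot show whether compound 2 and compound 3 would still match at higher concentrations, so their relative potency remains unknown.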